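Swapping the Sulfonamide Amine of Compound 1

The source may hold more compounds than are shown below. What is called first, only, known or untested is meant among the compounds shown, and "the series" means these compounds.

Measured so far in an in vitro ADME assay on microsomes from liver (Homo sapiens) for metabolic stability, read by LC-MS, tested at 1 uM; on this read-out higher numbers stand for fast clearance and lower numbers for slow clearance:
- compound 1, `Cc1ccc(S(=O)(=O)N(C)CC(C)C)cc1C#Cc1cc(Cl)ccc1OCC(=O)O`, gives 79 mL.min-1.g-1
- compound 2, `CCCS(=O)(=O)c1ccc(F)c(C#Cc2cc(Cl)ccc2OCC(=O)O)c1`, gives 12 mL.min-1.g-1
- compound 3, `CCCS(=O)(=O)c1cccc(C#Cc2cc(Cl)ccc2OCC(=O)O)c1`, gives 11 mL.min-1.g-1

Compound 1 stands highest of the three numbers in this assay; compound 2 and compound 3 both sit well below it, with gaps beyond the scatter. Going by the values given here, the one step that has been measured, a 1.1-fold lower number from compound 2 to compound 3 (0.04 log units; within the scatter), concerns the presence of a fluoro group and stays within the scatter.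

Compound 4, `Cc1ccc(S(=O)(=O)N2CCOCC2)cc1C#Cc1cc(Cl)ccc1OCC(=O)O`, is the next compound to be measured. It differs from compound 1 in one place: morpholin-4-yl in place of isobutyl(methyl)amino on a sulfonyl sulfur. Among the compounds with values here, no measured step touches this part of the structure, so nothing among the three compounds tells directly what to expect. Compound 2 and compound 3 show only that other sulfonyl substituents in this series can go with much lower numbers than compound 1. On that thin basis a modest move downward is estimated, a 2.3-fold lower number from compound 1 to compound 4 (0.35 log units; beyond the scatter), with wide uncertainty. For compound 4 the expected value is 35 mL.min-1.g-1, in the range 14 mL.min-1.g-1 to 85 mL.min-1.g-1.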

Compound 4, intrinsic clearance in microsomes: < 10 mL.min-1.g-1
Compound 4: only a limit was reported; the forecaster's own chance of this, stated with the estimate: 5%; middle value at least 3.5-fold (0.54 log units) away from the limit.
By their numbers in this assay, from the lowest: compounds 3 and 2 (each within the scatter of the next); then compound 1. At a limit, below all of these: compound 4.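

In this assay, compound 4 gives < 10 mL.min-1.g-1, which is a limit of the assay and not a number. Going by these compounds alone, putting morpholin-4-yl in place of isobutyl(methyl)amino on a sulfonyl sulfur gives an at least 7.9-fold lower number from compound 1 to compound 4 (0.89 log units; beyond the scatter), so this position, which no earlier step touched, can by itself move the clearance read-out by more than the usual scatter. The step gives only a minimum size, and how far compound 4 really lies under the limit cannot be read: the limit of < 10 mL.min-1.g-1 in this assay, at which 1 of the 4 values shown sits.

The compounds shown leave open whether the ring or its oxygen goes with the change, which piperidin-1-yl, with carbon in place of that oxygen, could help to separate. They also leave open how a small open-chain group such as dimethylamino would behave on the same sulfonyl sulfur.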